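Methylsulfanyl to hydroxy on the benzyl group of compound 1

This account rests on a few compounds, and the source may have more. Where it says the series, first, only, none or still open, it means among the compounds named here.

Among the compounds with values here, in a functional assay (Homo sapiens) for inhibition (on this read-out higher numbers stand for weaker inhibition and lower numbers for stronger inhibition), compound 1 `CSc1ccccc1CSc1nc(-c2ccc(F)cc2)c(-c2ccncc2)[nH]1` gives 6700 nM, the highest of the three numbers so far. Compound 2 `C[S+]([O-])c1ccc(CSc2nc(-c3ccc(Br)cc3)c(-c3ccncc3)[nH]2)cc1` gives 820 nM and compound 3 `CS(=O)(=O)c1ccc(CSc2nc(-c3ccc(Br)cc3)c(-c3ccncc3)[nH]2)cc1` gives 640 nM, both beyond the scatter from compound 1, but these two differ from compound 1 in more than one place. Within the data shown here, the only measured step, a 1.3-fold lower number from compound 2 to compound 3 (0.11 log units; within the scatter), lies within the scatter and involves neither methylsulfanyl nor hydroxy, so it offers weak guidance.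

Compound 4 `Oc1ccccc1CSc1nc(-c2ccc(F)cc2)c(-c2ccncc2)[nH]1` differs from compound 1 as follows: hydroxy in place of methylsulfanyl on an aromatic carbon. This places hydroxy in place of methylsulfanyl on an aromatic carbon, ortho to a large group. Among the measured compounds shown here, no measured step covers this exchange. Compound 1 at 6700 nM sits at the top of the series, so a downward move is judged the likelier one. A modest step of a 2.2-fold lower number from compound 1 to compound 4 (0.35 log units; beyond the scatter) is expected in this assay, and it may not clear the scatter. The estimate for compound 4 is 3000 nM, with an expected range of 700 nM to 10000 nM.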

Compound 4, half-maximal inhibitory concentration: 440 nM
For compound 4 the middle estimate is 6.8-fold (0.83 log units) above the measured one; the measured number lies below the stated range.
By their numbers in this assay, from the lowest: compounds 4, 3 and 2 (each within the scatter of the next); then compound 1.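

In this assay, the exchange of methylsulfanyl for hydroxy on an aromatic carbon, ortho to a large group, gives a 15-fold lower number from compound 1 to compound 4 (1.18 log units; beyond the scatter), a large step beyond the scatter. Within the data shown here, this is the first measured change at this place on the benzyl group, and it shows that the read-out responds strongly to the group held there, while the one earlier step, on a different group, stayed within the scatter. Nothing measured here accounts for the size of this step.

From the compounds shown here alone, whether the step reflects the arrival of hydroxy or the departure of methylsulfanyl stays open, and methoxy, an amine or a carboxylic acid at this place would help separate the two. Going by these compounds, the exchange is also known on the background of compound 1 alone, so its size on other members remains unknown.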